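Moving the ethoxy group on the aniline of compound 1

A few compounds are considered here, and "the series" means these few. Any claim that something is new, unique, unknown or untested is made for them only; others in the source may bear on it.

Compound 1 `FC(F)(F)c1ccc(CSc2nc(Nc3ccccc3C(F)(F)F)c3ccccc3n2)cc1` is one of three quinazoline-type compounds measured in a functional assay on PC-3 cells (Homo sapiens) for cytotoxicity, read by MTT assay, with a stated time of 72 h (a higher number here means a weaker inhibitor, a lower number a stronger inhibitor), where compound 1 gives 34800 nM, the highest of the three numbers. Compound 2 `CCOc1ccccc1Nc1nc(SCc2ccc(C(F)(F)F)cc2)nc2ccccc12` gives 26200 nM in this assay, and compound 3 `FC(F)(F)c1ccc(CSc2nc(Nc3cccc(Cl)c3)c3ccccc3n2)cc1` gives 13400 nM. The steps between them are small: a 1.3-fold lower number from compound 1 to compound 2 (0.12 log units; within the scatter), a 2.6-fold lower number from compound 1 to compound 3 (0.41 log units; beyond the scatter), and a 2.0-fold lower number from compound 2 to compound 3 (0.29 log units; within the scatter).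

Compound 4 `CCOc1ccc(Nc2nc(SCc3ccc(C(F)(F)F)cc3)nc3ccccc23)cc1` has not yet been measured in this assay. It differs from compound 1 in one place: 4-ethoxyphenyl in place of 2-(trifluoromethyl)phenyl on a nitrogen on an aromatic ring. Going by the values given here, two measured steps bear on this change. The step from compound 1 to compound 2 exchanges trifluoromethyl for ethoxy on the same aniline and stays within the scatter, a 1.3-fold lower number from compound 1 to compound 2 (0.12 log units; within the scatter). The step from compound 1 to compound 3 replaces the whole aryl group on the nitrogen and gives a modest improvement, a 2.6-fold lower number from compound 1 to compound 3 (0.41 log units; beyond the scatter). Taken together these suggest that a change of the aryl group on this nitrogen moves the number only a little, and in the direction of a lower number if at all. Compound 4 is therefore expected to show a 1.6-fold lower number from compound 1 to compound 4 (0.20 log units; within the scatter), a step that may well fall within the scatter. The estimate for compound 4 in this assay is 22000 nM, within a range from 9000 nM to 55000 nM.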

Compound 4, half-maximal inhibitory concentration: 32100 nM
Compound 4: middle estimate off by 1.5-fold (0.16 log units), on the low side; the range from low to high includes it.
By their numbers in this assay, from the lowest: compounds 3, 2, 4 and 1 (each within the scatter of the next, the first and the last beyond it).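

In this assay, 4-ethoxyphenyl on this nitrogen cannot be told apart from 2-(trifluoromethyl)phenyl (a 1.1-fold lower number from compound 1 to compound 4 (0.04 log units; within the scatter)) or from 2-ethoxyphenyl (a 1.2-fold higher number from compound 2 to compound 4 (0.09 log units; within the scatter)), so neither exchanging trifluoromethyl for ethoxy nor the different ethoxy-bearing aryl group separates compound 4 from these two neighbours. Going by these compounds alone, the only step from compound 4 that clears the scatter is the one to the 3-chlorophenyl compound (a 2.4-fold higher number from compound 3 to compound 4 (0.38 log units; beyond the scatter)), which gives compound 3 a modest edge over compound 4 and compound 1, though compound 2 goes against any clean split because it stays within the scatter of compound 3. No measurement offered here explains why these aryl groups give such similar numbers.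

The compounds shown leave open whether the modest edge of compound 3 belongs to chlorine itself or would survive with bromine, a nitrile or a methyl group on the same phenyl ring. They also leave open whether an amine or a carboxylic acid on that ring would move the number further than any of the aryl groups seen so far.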